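Cyclobutyl for Fluorophenyl in a Series

A few compounds are considered here, and "the series" means these few. Any claim that something is new, unique, unknown or untested is made for them only; others in the source may bear on it.

Of the compounds shown here, three have been measured in an assay for inhibition of Pro-cathepsin H (Homo sapiens), read by fluorescence, tested at 50 uM; on this read-out lower numbers stand for less inhibition and higher numbers for more inhibition at the one concentration tested (going by the name of the read-out). Compound 1 `O=c1nc(-c2ccccc2)nc(S)[nH]1` gives 4.86%. Compound 2 `Cc1ccc(-c2nc(S)[nH]c(=O)n2)cc1`, which carries methyl in place of hydrogen on an aromatic carbon, gives 6.58%; the step reads a number 1.7 percentage points higher from compound 1 to compound 2 (within the scatter). Compound 3 `O=c1nc(SCc2ccccc2)nc(SCc2cccc(F)c2)[nH]1` gives 4.18%, the lowest of the three numbers, though its gaps to compound 1 and to compound 2 are both within the scatter, so none of the three can be set apart from the others on these numbers.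

Compound 4 `O=c1nc(SCc2ccccc2)nc(SCC2CCC2)[nH]1` is the next compound to be tested in this assay. It differs from compound 3 in one place: cyclobutyl in place of 3-fluorophenyl on a saturated chain carbon bound to a sulfur. Among the compounds with values here, no measured step bears directly on this change. Within the data shown here, the one measured step, from compound 1 to compound 2, concerns a different part of the molecule and stayed within the scatter, and all three measured numbers sit close together near the bottom of the scale. With nothing in the measured data pointing to a change, compound 4 is expected to show no step beyond the scatter, a number 0.8 percentage points higher from compound 3 to compound 4 (within the scatter). Compound 4 is therefore estimated at 5%, with a range from -5% to 15%.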

Compound 4, a percentage reported as inhibition, at one concentration (the size of the read-out at that concentration, not a potency): 1.57%
The estimate for compound 4 lay 3.4 percentage points above the measured number; the measured number falls inside the stated range.
By their numbers in this assay, from the lowest: compounds 4, 3, 1 and 2 (each within the scatter of the next).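

In this assay, within the data shown here, the step at this position is the first to test the group on a saturated chain carbon bound to a sulfur, and it reads a number 2.6 percentage points lower from compound 3 to compound 4 (within the scatter). Replacing 3-fluorophenyl with cyclobutyl removes the aromatic ring and the fluorine and reduces the group from 7 heavy atoms to 4, yet the number does not move beyond the scatter, so this change cannot be told apart from no change at this one concentration. Nothing on hand accounts for the step or its size.

The compounds shown leave open whether a group of another kind at this place, such as an amine, a carboxylic acid or a longer chain, would move the number beyond the scatter in this assay. They also leave open whether any such change would behave the same way with something other than the benzyl group on the other sulfur, since both compound 3 and compound 4 carry that group.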